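Lengthening the Alkenyl Chain on the Shared Core

The source may report more compounds than this note shows. Statements on the series, on what has been measured and on what is new or still open speak of the compounds shown alone.

Measured so far in a functional assay on the whole organism (Abdomen, strain Swiss) for inhibition, with Mus musculus as the target, with stated times of 30 min, 10 min and 5 min, at a dose of 40 mg/kg by the oral route; on this read-out lower numbers stand for a weaker effect and higher numbers for a stronger effect at the one dose given:
compound 1, `CCC(=O)c1c(C)nn(CCCN2CCN(c3ccc(C)cc3)CC2)c(=O)c1N`: 29%
compound 2, `CC/C=C/c1c(C)nn(CCCN2CCN(c3ccc(C)cc3)CC2)c(=O)c1N`: 45%

Among the measured compounds shown here, compound 2 stands highest of the two numbers in this assay; its nearest neighbour is compound 1, and the one step so far, a number 16 percentage points higher from compound 1 to compound 2 (beyond the scatter), came with but-1-en-1-yl in place of propanoyl on an aromatic carbon. That step lies beyond the scatter and is modest in size.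

The next compound, compound 3 `CCC/C=C/c1c(C)nn(CCCN2CCN(c3ccc(C)cc3)CC2)c(=O)c1N`, differs from compound 2 by methyl in place of hydrogen on a saturated chain carbon, two bonds along the chain from a double-bonded chain carbon. The chain is thus extended by one saturated carbon, but the double-bonded chain carbon and everything else on the shared core stay as they are.

For the measured compounds named here, no measured step bears directly on this change: the one step available concerns swapping a carbonyl-bearing group for an alkenyl group, not lengthening an alkenyl chain. The best guess is therefore a step no larger than the scatter. Compound 3 is expected to give about 45%, within 30% to 60%, which means an expected step of no change at the digits printed from compound 2 to compound 3 (within the scatter).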

Compound 3, a percentage reported as inhibition, in the whole organism at one dose (the size of the read-out at that dose, not a potency): 36%
Compound 3: middle estimate off by 9 percentage points, on the high side; the measured number falls inside the stated range.
By their numbers in this assay, from the lowest: compounds 1, 3 and 2 (each within the scatter of the next, the first and the last beyond it).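

In this assay, among the compounds shown here, the extension of but-1-en-1-yl to pent-1-en-1-yl gives a number 9 percentage points lower from compound 2 to compound 3 (within the scatter), the first reading on the length of this chain, and the added methyl on a saturated chain carbon does not separate the two compounds at this dose. Replacing propanoyl with pent-1-en-1-yl gives a number 7 percentage points higher from compound 1 to compound 3 (within the scatter), whereas replacing it with but-1-en-1-yl gave a number 16 percentage points higher from compound 1 to compound 2 (beyond the scatter), so the clear separation from compound 1 holds for only one of these two alkenyl groups, and compound 3 cannot be told apart from either neighbour. Nothing at hand explains these numbers.

The compounds shown leave open whether a longer chain such as hept-1-en-1-yl would move the read-out beyond the scatter from compound 2, or whether the short series simply stays flat over this length. They also leave open whether the double bond matters at all, which a saturated pentyl chain would test, and whether a hydroxyl or an amine at the end of the pent-1-en-1-yl chain would change the read-out.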